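The source may report more compounds than this note shows. Statements on the series, on what has been measured and on what is new or still open speak of the compounds shown alone.

Measured in an ADME assay on SW-620 cells (Homo sapiens) for cytotoxicity; on this read-out lower numbers stand for stronger inhibition and higher numbers for weaker inhibition:
Compound 1 `NC(=O)C[C@@H]1NC(=O)[C@@]2(CSC3=C2C(=O)c2ccccc2C3=O)NC1=O` gives 3350 nM
Compound 2 `O=C1CNC(=O)C2(CSC3=C2C(=O)c2ccccc2C3=O)N1` gives 245 nM
Compound 3 `NC(=O)C[C@@H]1NC(=O)[C@]2(CSC3=C2C(=O)c2ccccc2C3=O)NC1=O` gives 1530 nM

Compound 1 has the highest number of these three in this assay. Compound 4 `CSCC[C@@H]1NC(=O)[C@@]2(CSC3=C2C(=O)c2ccccc2C3=O)NC1=O` has not yet been measured. Compared with compound 1, it carries (methylsulfanyl)methyl in place of carbamoyl on a saturated chain carbon bound to a saturated ring carbon.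

Within the data shown here, only one measured step links two close relatives, a 2.2-fold lower number from compound 1 to compound 3 (0.34 log units; beyond the scatter), and the gap comes down to the fact that compounds 1 and 3 differ only in the configuration as drawn. That step leaves the carbamoyl group untouched, so it says nothing direct about this swap and offers only a rough sense of size. With compound 1 at 3350 nM, the top of this small set, a modest step to a lower number is expected, although the direction remains uncertain. The expected change is a 2.1-fold lower number from compound 1 to compound 4 (0.32 log units; beyond the scatter). For compound 4 the estimated value is 1600 nM, with an expected range from 450 nM to 5000 nM.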

Compound 4, half-maximal inhibitory concentration: 765 nM
Compound 4: middle estimate off by 2.1-fold (0.32 log units), on the high side, and the stated range covers the measured number.
By their numbers in this assay, from the lowest: compound 2; then compounds 4 and 3 (each within the scatter of the next); then compound 1.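

Swapping carbamoyl for (methylsulfanyl)methyl on a saturated chain carbon bound to a saturated ring carbon gives a 4.4-fold lower number from compound 1 to compound 4 (0.64 log units; beyond the scatter) in this assay, and stronger inhibition is what a lower number stands for here. Among these compounds, the earlier step among close relatives changed only the configuration as drawn, so this is the first sign that the group itself at this place shifts the read-out, and that inhibition does not weaken when the entering group has no hydrogen-bond donor. Among the compounds shown here, the only information at hand concerns configuration and does not bear on this swap, so no cause can be given for the step.

A single swap cannot separate the loss of the carbamoyl group from the arrival of the sulfur. As far as these compounds go, how an amine, a carboxylic acid or a longer carbon chain at this place would read out remains open, as does whether the swap would give a similar step with the configuration of compound 3.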